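This account rests on a few compounds, and the source may have more. Where it says the series, first, only, none or still open, it means among the compounds named here.

Compound 1 `Fc1ccc(-c2cn3ccnc3c(-c3ccc4ncn(C5CCCCC5)c4c3)n2)cc1` and compound 2 `Fc1ccccc1-c1cn2ccnc2c(-c2ccc3ncn(C4CCCCC4)c3c2)n1` share one core and differ only in the fluorophenyl ring attached to it. In a functional assay on PC-3 cells (Homo sapiens) for inhibition, read by sulforhodamine B assay, with a stated time of 48 h, tested at 10 uM (a higher number here means more inhibition at the concentration tested (going by the name of the read-out), a lower number less inhibition), compound 1 gives 53.6%, while compound 2 gives 32.6%, the lowest of the two numbers; the step of a number 21 percentage points lower from compound 1 to compound 2 (beyond the scatter) lies beyond the scatter. Compound 3 `FC(F)(F)c1cccc(-c2cn3ccnc3c(-c3ccc4ncn(C5CCCCC5)c4c3)n2)c1` carries the change (3-(trifluoromethyl)phenyl in place of 2-fluorophenyl on an aromatic carbon). For the measured compounds named here, only that single step bears on swapping this ring, and it shows a modest loss, so a partial recovery upward is expected rather than none. The expected step is a number 12.4 percentage points higher from compound 2 to compound 3 (beyond the scatter). Compound 3 is therefore estimated at 45%, spanning 20% to 70%.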

Compound 3, a percentage reported as inhibition, at one concentration (the size of the read-out at that concentration, not a potency): 36.5%
Estimate against measurement, compound 3: 8.5 percentage points above; measured number inside the range.
By their numbers in this assay, from the lowest: compounds 2 and 3 (each within the scatter of the next); then compound 1.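

In this assay, replacing 2-fluorophenyl with 3-(trifluoromethyl)phenyl gives a number 3.9 percentage points higher from compound 2 to compound 3 (within the scatter) and so does not separate these two rings. The comparison with the first ring gives a number 17.1 percentage points lower from compound 1 to compound 3 (beyond the scatter) and shows that compound 1, with 4-fluorophenyl, now stands apart from two different replacements rather than one. Nothing available explains these differences. Still open, from the compounds shown here alone, is how a phenyl ring carrying an amine or a carboxylic acid would behave at this position, and whether any replacement could match or pass compound 1.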